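Butoxy in place of benzyloxy on the shared core

A few compounds are considered here, and "the series" means these few. Any claim that something is new, unique, unknown or untested is made for them only; others in the source may bear on it.

Compound 1 `c1ccc(COc2cc(-c3ccccc3)nc3ccccc23)cc1` carries a benzyloxy group on its core. In a functional assay on L1210 (1565) cells (Mus musculus) for cytotoxicity (a lower number here means that less compound is needed, a higher number that more compound is needed for the effect), compound 1 gives only a limit, > 10 ug/mL, which marks the edge of the assay rather than a number (the limit of > 10 ug/mL in this assay, at which 1 of the 2 values shown sits). Compound 2 `Oc1ccc2nc(-c3ccccc3)cc(O)c2c1`, bearing two hydroxy groups on the same core, is measured in this assay at 0.83 ug/mL. For the measured compounds named here, no single-change step connects compound 2 to compound 1, so the two values simply stand side by side. Compound 3 `CCCCOc1cc(-c2ccccc2)nc2ccccc12` is not yet measured. It differs from compound 1 by propyl in place of phenyl on a saturated chain carbon bound to an oxygen on an aromatic ring. No measured step of this kind exists among the compounds shown, so the size of the change in this assay is open. The step expected from this change is a step that the limit leaves unreadable from compound 1 to compound 3, none beyond the scatter, because compound 1 sits at the limit (the limit of > 10 ug/mL in this assay, at which 1 of the 2 values shown sits). Compound 3 is therefore expected to give 15 ug/mL, between 5 ug/mL and 50 ug/mL, with a fair chance that again only a limit is reported.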

Compound 3, half-maximal effective concentration: > 10 ug/mL
Compound 3 was reported as a limit (the forecaster's own chance of this, stated with the estimate: 70%); the middle value does not contradict the limit.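

In this assay compound 3 gives > 10 ug/mL, which is a limit, and compound 1 also sits at a limit, so no step can be read between the two: the limit of > 10 ug/mL in this assay, at which 2 of the 3 values shown sit.

On these data alone, whether butoxy and benzyloxy differ at all in this read-out remains open.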